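Removing the methoxy group: from compound 1 to compound 3

The source may hold more compounds than are shown below. What is called first, only, known or untested is meant among the compounds shown, and "the series" means these compounds.

Measured compounds:
compound 1 `COc1ccc(/C(=C\c2c[nH]c3ccc(OCc4ccccc4)cc23)C(=O)O)cc1` — > 100000 nM
compound 2 `COc1ccc(/C(=C\c2cn(C(C)=O)c3ccc(OCc4ccccc4)cc23)C(=O)O)cc1` — "not determined" (no result reported)

Compound 1 was tested in a functional assay on Caco-2 cells (Homo sapiens) for cytotoxicity, read by MTT assay, with a stated time of 72 h; on this read-out lower numbers stand for stronger inhibition and higher numbers for weaker inhibition. In this assay compound 1 gives > 100000 nM, which is a limit of the assay and not a measured number. Its standing is therefore fixed only by the limit of > 100000 nM in this assay, at which 1 of the 2 values shown sits, with nothing below or beyond it known. Compound 2 was also entered into this assay, but for compound 2 the result is "not determined" (no result reported), so no value exists for comparison, and nothing can be said of what its acetyl group does.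

Compound 3 `O=C(O)/C(=C/c1c[nH]c2ccc(OCc3ccccc3)cc12)c1ccccc1` has not yet been measured. It differs from compound 1 by hydrogen in place of methoxy on an aromatic carbon. Among the compounds with values here, no measured step connects any two compounds here, because compound 1 sits at a limit. The change from compound 1 to compound 3 is expected to give no shift beyond the usual scatter in this assay, and the step that the limit leaves unreadable from compound 1 to compound 3 is estimated with the likelihood that the assay again reports only a limit. Compound 3 is expected at 120000 nM, within a range from 40000 nM to 400000 nM.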

Compound 3, half-maximal inhibitory concentration: 41600 nM
For compound 3 the middle estimate is 2.9-fold (0.46 log units) above the measured one, and the stated range covers the measured number.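

In this assay, within the data shown here, the change from 4-methoxyphenyl to phenyl gives an at least 2.4-fold lower number from compound 1 to compound 3 (0.38 log units; beyond the scatter) and this is the first step that can be read at all. It shows that the place on the aromatic carbon, para to a large group, is not indifferent to what it carries, and that hydrogen there goes with the lower number, which is still a weak one on this read-out. The size of the step is only a lower bound, because compound 1 stands at a limit of the assay and not at a measured number: the limit of > 100000 nM in this assay, at which 1 of the 3 values shown sits.

One pair cannot tell whether the lower number follows from the loss of methoxy alone or whether other groups at this place, such as a hydroxyl, a chlorine or an amine, would lower it further or raise it again. The acetyl group of compound 2 remains unreadable with no result reported, and so the compounds shown say nothing yet about the indole nitrogen's substituent, nor about the benzyloxy group or the carboxylic acid.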